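The compounds below may be only part of what the source reports. "The series", "measured", "known", "first", "only" and "open" are said of these compounds alone.

Compound 2 `COc1ccc(CN2CCC(c3noc(COc4ccc(/C=C/C(=O)NO)cc4)n3)CC2)cc1` is tested in an assay on isolated protein for inhibition of protein deacetylase HDAC6 (Homo sapiens), read by fluorescence, with a stated time of 1 h, tested at 100 nM (a higher number here means more inhibition at the concentration tested (going by the name of the read-out), a lower number less inhibition), and gives 75%; compound 1 `O=C(/C=C/c1ccc(OCc2nc(C3CCN(Cc4ccc(F)cc4)CC3)no2)cc1)NO` gives 75%, so the two stand level, with no change at the digits printed from compound 1 to compound 2 (within the scatter). Compound 3 `N#Cc1ccc(CN2CCC(c3noc(COc4ccc(/C=C/C(=O)NO)cc4)n3)CC2)cc1` differs from compound 2 by cyano in place of methoxy on an aromatic carbon. Among the compounds with values here, no measured step exchanges a methoxy for a cyano; the only step known, the one from compound 1 to compound 2, swapped another group at this position and moved nothing beyond the scatter. For compound 3 a step of a number 3 percentage points lower from compound 2 to compound 3 (within the scatter) is therefore expected, that is, none beyond the scatter. Compound 3 is estimated at 72%, within a range of 55% to 86%.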

Compound 3, a percentage reported as inhibition, at one concentration (the size of the read-out at that concentration, not a potency): 65%
Estimate against measurement, compound 3: 7 percentage points above; the range from low to high includes it.
By their numbers in this assay, from the lowest: compounds 3, 1 and 2 (each within the scatter of the next).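

In this assay, cyano in place of methoxy gives a number 10 percentage points lower from compound 2 to compound 3 (within the scatter), and cyano in place of fluoro gives a number 10 percentage points lower from compound 1 to compound 3 (within the scatter). This para position on the benzyl ring has now carried three different groups, fluoro, methoxy and cyano, with no step beyond the scatter, so the earlier single swap now extends to a third group. Nothing available explains these readings.

Still open, as far as these compounds go, is whether an amine, a carboxylic acid or a longer chain at this position would keep the reading in the same range. A reading at one concentration also leaves open how the potencies of these compounds compare.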